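The source may hold more compounds than are shown below. What is called first, only, known or untested is meant among the compounds shown, and "the series" means these compounds.

Notes on the biaryl series in a functional assay on HeLa cells (Homo sapiens) for inhibition, with a stated time of 72 h; a lower number here means a stronger inhibitor, a higher number a weaker inhibitor. Compound 1 `NC1CCC(Nc2nc(NCc3ccc(-c4ccccc4)cc3)c3ncn(C4CCCC4)c3n2)CC1` gives 240 nM, compound 2 `COc1ccccc1-c1ccc(CNc2nc(NC3CCC(N)CC3)nc3c2ncn3C2CCCC2)cc1` gives 333 nM, and compound 3 `NC1CCC(Nc2nc(NCc3ccc(-c4ccsc4)cc3)c3ncn(C4CCCC4)c3n2)CC1` gives 220 nM. The numbers place compound 3 within the scatter of both others: a 1.1-fold lower number from compound 1 to compound 3 (0.04 log units; within the scatter), and a 1.5-fold lower number from compound 2 to compound 3 (0.18 log units; within the scatter).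

Compound 4 `NC1CCC(Nc2nc(NCc3ccc(-n4cccn4)cc3)c3ncn(C4CCCC4)c3n2)CC1` changes only the terminal ring of compound 3: 1H-pyrazol-1-yl in place of thiophen-3-yl on an aromatic carbon. This puts 1H-pyrazol-1-yl in place of thiophen-3-yl on the same aromatic carbon.

For the measured compounds named here, no measured compound carries this group, so the evidence is indirect. The closest guide is the exchange at the same place that leads to compound 3, a 1.1-fold lower number from compound 1 to compound 3 (0.04 log units; within the scatter). The change from compound 2 to compound 3 at that place, a 1.5-fold lower number from compound 2 to compound 3 (0.18 log units; within the scatter), also stayed small, as did the methoxy addition, a 1.4-fold higher number from compound 1 to compound 2 (0.14 log units; within the scatter). All three compounds tolerate these changes without a step beyond the scatter, and none is therefore expected in this assay here.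

The expected step is a 1.1-fold higher number from compound 3 to compound 4 (0.06 log units; within the scatter). For compound 4 the estimated value is 250 nM, with an expected range of 120 nM to 520 nM.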

Compound 4, half-maximal inhibitory concentration: 170 nM
Beside the measured number, compound 4's estimate is 1.5-fold (0.17 log units) above it; the measured number falls inside the stated range.
By their numbers in this assay, from the lowest: compounds 4, 3, 1 and 2 (each within the scatter of the next).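

In this assay, the position on an aromatic carbon para to a large group also takes a five-membered aromatic ring with 2 hetero atoms, both nitrogen, and 2 hydrogen-bond acceptors: a 1.3-fold lower number from compound 3 to compound 4 (0.11 log units; within the scatter) stays within the scatter. The other two exchanges, a 1.4-fold lower number from compound 1 to compound 4 (0.15 log units; within the scatter) and a 2.0-fold lower number from compound 2 to compound 4 (0.29 log units; within the scatter), are also within it, so phenyl, 2-methoxyphenyl, thiophen-3-yl and 1H-pyrazol-1-yl cannot be told apart in this assay. No available measurement bears on the reason for this result.

Still open, from the compounds shown here alone, is whether any group at this position gives a step beyond the scatter, for example a carboxylic acid, a primary amine or a longer alkyl chain in place of the terminal ring. Also open, going by these compounds, is whether 1H-imidazol-1-yl, with its nitrogens placed differently, would read like 1H-pyrazol-1-yl.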